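Aryl ring swap at the distal phenoxy group

A few compounds are considered here, and "the series" means these few. Any claim that something is new, unique, unknown or untested is made for them only; others in the source may bear on it.

Measured compounds:
compound 1 `N[C@@H](COP(=O)(O)OCCCOC(=O)CCc1ccccc1OCc1cccc(Oc2ccccc2)c1)C(=O)O` gives 19.4% in an assay on cells for agonist activity at probable G-protein coupled receptor 34 (Mus musculus), with a stated time of 1 h; a higher number here means a larger maximal response, a lower number a smaller maximal response.
compound 2 `Cc1ccc(Oc2cccc(COc3ccccc3CCC(=O)OCCCOP(=O)(O)OC[C@H](N)C(=O)O)c2)cc1` gives 18.2% in this assay.
compound 3 `N[C@@H](COP(=O)(O)OCCCOC(=O)CCc1ccccc1OCc1cccc(Oc2ccccc2Cl)c1)C(=O)O` gives 19.8% in this assay.

For the measured compounds named here, compound 3 shows the highest of the three numbers, but this says little: its nearest neighbour is compound 1 a number 0.4 percentage points higher from compound 1 to compound 3 (within the scatter), and compound 2 lies furthest away a number 1.6 percentage points higher from compound 2 to compound 3 (within the scatter), both within the scatter, so no compound can be called the most active.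

Compound 4 `N[C@@H](COP(=O)(O)OCCCOC(=O)CCc1ccccc1OCc1cccc(Oc2ccc(F)cc2)c1)C(=O)O` is not yet measured. It differs from compound 3 in one place: 4-fluorophenyl in place of 2-chlorophenyl on an oxygen on an aromatic ring

Going by the values given here, the steps that bear on this change are the three small ones already seen, a number 1.2 percentage points lower from compound 1 to compound 2 (within the scatter), a number 0.4 percentage points higher from compound 1 to compound 3 (within the scatter) and a number 1.6 percentage points higher from compound 2 to compound 3 (within the scatter), all within the scatter, each of them a swap of a substituent on the same distal aromatic ring. None of them moved the maximal response beyond noise, so no step beyond the scatter is expected here either, in neither direction.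

Compound 4 is therefore expected to give 19%, with a range from 10% to 28%. The expected step from compound 3 is a number 0.8 percentage points lower from compound 3 to compound 4 (within the scatter).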

Compound 4, largest response reached (Emax), in percent of the reference or control that the assay uses: 18.7%
The estimate for compound 4 lay 0.3 percentage points above the measured number; measured number inside the range.
By their numbers in this assay, from the lowest: compounds 2, 4, 1 and 3 (each within the scatter of the next).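

In this assay, replacing 2-chlorophenyl with 4-fluorophenyl on the oxygen gives a number 1.1 percentage points lower from compound 3 to compound 4 (within the scatter), so changing the halogen and its place on the ring in a single swap still leaves the maximal response unresolved. Fluoro in place of methyl gives a number 0.5 percentage points higher from compound 2 to compound 4 (within the scatter), and fluoro in place of hydrogen gives a number 0.7 percentage points lower from compound 1 to compound 4 (within the scatter), so the four compounds, which carry hydrogen, methyl, chloro or fluoro on this distal ring, cannot be told apart in this read-out. No evidence is available to explain this result.

On these data alone, it remains open whether an amine or a carboxylic acid on this ring would move the response beyond the scatter. Also open, as far as these compounds go, is whether a pyridine ring in place of the distal phenyl, or an amide in place of the ester, would do so.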